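This account rests on a few compounds, and the source may have more. Where it says the series, first, only, none or still open, it means among the compounds named here.

Measured so far:
compound 1 `Nc1cc(Oc2ccc(NC(=O)Nc3cccc(C(F)(F)F)c3)cc2)ncn1` — 25 nM
compound 2 `CNc1cc(Oc2ccc(NC(=O)Nc3cccc(C(C)F)c3)cc2)ncn1` — 79 nM

In an assay on isolated protein for inhibition of serine/threonine-protein kinase TNNI3K (Homo sapiens) (on this read-out higher numbers stand for weaker inhibition and lower numbers for stronger inhibition), compound 1 gives 25 nM, the lower of the two numbers; compound 2 gives 79 nM, and the gap between them lies beyond the usual scatter. Compound 3 `CC(=O)Nc1cc(Oc2ccc(NC(=O)Nc3cccc(C(F)(F)F)c3)cc2)ncn1` is not yet measured; it differs from compound 1 by acetyl in place of hydrogen on a nitrogen on an aromatic ring. For the measured compounds named here, no measured pair shows this change. A modest weakening is expected, as the only departure seen so far from compound 1, in compound 2, gave a higher number. The expected step of a 3.2-fold higher number from compound 1 to compound 3 (0.51 log units; beyond the scatter) is small but beyond the scatter. Compound 3 is estimated at 80 nM, range 25 nM to 300 nM.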

Compound 3, half-maximal inhibitory concentration: 20 nM
For compound 3 the middle estimate is 4.0-fold (0.60 log units) above the measured one; measured number below the stated range.
By their numbers in this assay, from the lowest: compounds 3 and 1 (each within the scatter of the next); then compound 2.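

In this assay the change from amino to acetamido gives a 1.3-fold lower number from compound 1 to compound 3 (0.10 log units; within the scatter) and so stays within the scatter. This nitrogen on an aromatic ring therefore carries an acetyl group without a measurable loss, which compound 2 could not show, as it differs from compound 1 in two places. No measurement at hand accounts for this result.

Still open, going by these compounds, is whether a longer acyl chain, a sulfonamide or a carboxylic acid on this nitrogen would behave like acetyl. Also open, on these data alone, is whether acetamido holds up with a group other than trifluoromethyl elsewhere on the shared core.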